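Tolerated concentrations across four related compounds

This account rests on a few compounds, and the source may have more. Where it says the series, first, only, none or still open, it means among the compounds named here.

Compound 1 `COc1ccc(S(=O)(=O)N2CCC3(CC2)OOC2(CCCC2)OO3)cc1` is tested in a functional assay on Huh-7 cells (Homo sapiens) for cytotoxicity, read by MTT assay, with a stated time of 72 h (a higher number here means that more compound is tolerated, a lower number that less compound is tolerated), where compound 1 gives > 100 ug/mL, a limit of the assay rather than a number. Compound 3 `O=S(=O)(c1ccc(F)cc1)N1CCC2(CC1)OOC1(CCCC1)OO2` differs from compound 1 by fluoro in place of methoxy on an aromatic carbon; in this assay compound 3 reaches the limit > 100 ug/mL. The step that the two limits leave unreadable from compound 1 to compound 3 therefore cannot be sized. Compound 2 `COc1ccc(S(=O)(=O)N2CCC3(CC2)OOC2(CCCCCC2)OO3)cc1` carries another core; the difference between the two cores of compound 1 and compound 2 is not broken down here. In this assay compound 2 stops at the limit > 100 ug/mL. For the measured compounds named here, every value so far sits at the limit of > 100 ug/mL in this assay, at which 3 of the 3 values shown sit. Compound 4 `O=S(=O)(c1ccc(F)cc1)N1CCC2(CC1)OOC1(CCCCCC1)OO2`, not yet measured, differs from compound 2 by fluoro in place of methoxy on an aromatic carbon, the same change as from compound 1 to compound 3. Because compound 1 and compound 3 both sit at the limit of > 100 ug/mL in this assay, at which 3 of the 3 values shown sit, a step that the limit leaves unreadable from compound 2 to compound 4 is expected. Compound 4 is estimated at 150 ug/mL in this assay, most likely reported again only as a limit.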

Compound 4, half-maximal cytotoxic concentration: > 100 ug/mL
Compound 4: no number, only a limit; the forecaster's own chance of this, stated with the estimate: 85%; the middle value does not contradict the limit.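

No step can be read from compound 2 to compound 4, since both values are limits of the assay: the limit of > 100 ug/mL in this assay, at which 4 of the 4 values shown sit. The compounds shown leave open what concentration is actually tolerated in this assay, and whether fluoro in place of methoxy changes it.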